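The source may hold more compounds than are shown below. What is called first, only, known or untested is meant among the compounds shown, and "the series" means these compounds.

Measured compounds in the series:

- compound 1, `Cc1nn(-c2ncnc3nc[nH]c23)c2c1C(OCC(=O)c1ccc(F)cc1)CC(=O)N2`: 973 nM
- compound 2, `Cc1nn(-c2ncnc3nc[nH]c23)c2c1C(OC1CCCC1)CC(=O)N2`: 62 nM
- compound 3, `Cc1nn(-c2ncnc3nc[nH]c23)c2c1C(c1ccc(OC(C)C)cc1)CC(=O)N2`: 2700 nM

In a functional assay on HEK293 cells for agonist activity at G-protein coupled receptor 39 (Homo sapiens), read by scintillation proximity assay and inositol phosphate accumulation, with a stated time of 75 min (on this read-out lower numbers stand for an effect already at smaller amounts and higher numbers for an effect only at larger amounts of compound), compound 3 gives 2700 nM, the highest of the three numbers; compound 1 is nearest with 973 nM, compound 2 furthest with 62 nM, both steps beyond the scatter. Compound 4, `Cc1nn(-c2ncnc3nc[nH]c23)c2c1C(OC(=O)c1ccc(F)cc1)CC(=O)N2`, is not yet measured. The change from compound 3 is ((4-fluorophenyl)carbonyl)oxy in place of 4-isopropoxyphenyl on a saturated ring carbon. Going by the values given here, two measured steps bear on it. The step of a 44-fold higher number from compound 2 to compound 3 (1.64 log units; beyond the scatter) shows what moving from an oxygen-linked group to a directly attached aryl ring did, and compound 4 reverses that kind of change, which argues for a lower number. The step of a 16-fold lower number from compound 1 to compound 2 (1.20 log units; beyond the scatter) shows that an oxygen-linked fluorophenyl-carbonyl-bearing group sat well above cyclopentyl, and compound 4 carries a group of that sort, so the number for compound 1 is the closer reference. The expected step in this assay is therefore a 2.7-fold lower number from compound 3 to compound 4 (0.43 log units; beyond the scatter), a moderate decrease. Compound 4 is estimated at 1000 nM, range 300 nM to 3500 nM.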

Compound 4, half-maximal effective concentration: 245 nM
Compound 4: middle estimate off by 4.1-fold (0.61 log units), on the high side; the measured number lies below the stated range.
By their numbers in this assay, from the lowest: compound 2; then compound 4; then compound 1; then compound 3.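

In this assay, ((4-fluorophenyl)carbonyl)oxy in place of 4-isopropoxyphenyl on the saturated ring carbon gives an 11-fold lower number from compound 3 to compound 4 (1.04 log units; beyond the scatter), so a fluorophenyl-bearing group at this position can reach a much lower number than compound 3 suggested. Going by these compounds alone, on the oxygen, (4-fluorophenyl)carbonyl in place of ((4-fluorophenyl)carbonyl)methyl gives a 4.0-fold lower number from compound 1 to compound 4 (0.60 log units; beyond the scatter), which shows that the chain linking that oxygen to the fluorophenyl ring affects the number, something the earlier compounds could not separate. Even so, the same group in place of cyclopentyl gives a 4.0-fold higher number from compound 2 to compound 4 (0.60 log units; beyond the scatter), so cyclopentyl remains ahead of it on this oxygen.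

No evidence at hand accounts for any of these steps. Also open, on these data alone, is how an amine or a carboxylic acid in place of the fluorine, or a longer chain carrying the cyclopentyl on the oxygen, would read.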